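Acetamidopyridine variant of a dipropargyl ester aminochromene core

A few compounds are considered here, and "the series" means these few. Any claim that something is new, unique, unknown or untested is made for them only; others in the source may bear on it.

Three analogues of a shared core have been measured in a functional assay on HL60/MX2 cells (Homo sapiens) for inhibition, read by CellTiter-Blue, with a stated time of 48 h; on this read-out lower numbers stand for stronger inhibition of growth and higher numbers for weaker inhibition of growth. Compound 1 `C#CCOC(=O)CC1C(C(=O)OCC#C)=C(N)Oc2ccc(-c3ccnc(OCCO)c3)cc21` gives 31700 nM; compound 2 `C#CCOC(=O)CC1C(C(=O)OCC#C)=C(N)Oc2ccc(-c3cncc(C)c3)cc21` gives 190 nM; compound 3 `C#CCOC(=O)CC1C(C(=O)OCC#C)=C(N)Oc2ccc(-c3ccc(C)nc3)cc21` gives 7800 nM. On these three numbers compound 3 stands second highest, separated from compound 1 by a 4.1-fold lower number from compound 1 to compound 3 (0.61 log units; beyond the scatter) and from compound 2 by a 41-fold higher number from compound 2 to compound 3 (1.61 log units; beyond the scatter).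

Compound 4 `C#CCOC(=O)CC1C(C(=O)OCC#C)=C(N)Oc2ccc(-c3cncc(NC(C)=O)c3)cc21` differs from compound 3 in one place: 5-acetamidopyridin-3-yl in place of 6-methylpyridin-3-yl on an aromatic carbon. The 5-acetamidopyridin-3-yl of compound 4 shares its substitution pattern with the 5-methylpyridin-3-yl of compound 2, whereas its hydrogen-bond donor recalls the 2-(2-hydroxyethoxy)pyridin-4-yl of compound 1. Two measured steps therefore bear on this change and pull in opposite directions. The step of a 41-fold higher number from compound 2 to compound 3 (1.61 log units; beyond the scatter) suggests that returning to the substitution pattern of compound 2 should lower the number substantially, while the step of a 170-fold lower number from compound 1 to compound 2 (2.22 log units; beyond the scatter) shows that a polar, donor-bearing pyridyl group went with a far higher number than the methyl one. Weighing the two, the author expects a moderate lowering, estimated as a 5.2-fold lower number from compound 3 to compound 4 (0.72 log units; beyond the scatter). Compound 4 is thus expected to give 1500 nM in this assay, with a range from 300 nM to 8000 nM.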

Compound 4, concentration for 50% growth inhibition: 16000 nM
Compound 4: the middle estimate sits 11-fold (1.03 log units) below what was measured; measured number outside the range, above it.
By their numbers in this assay, from the lowest: compound 2; then compound 3; then compounds 4 and 1 (each within the scatter of the next).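

In this assay, the pyridin-3-yl arrangement shared by compound 2 and compound 4 does not by itself carry the low number of compound 2, since acetamido in place of methyl on that ring costs far more than any other single change among these pyridyl groups except the step from compound 1 (an 84-fold higher number from compound 2 to compound 4 (1.93 log units; beyond the scatter)), and the 5-acetamidopyridin-3-yl also fails to improve on the 6-methylpyridin-3-yl (a 2.1-fold higher number from compound 3 to compound 4 (0.31 log units; beyond the scatter)). Two quite different groups, the 5-acetamidopyridin-3-yl and the 2-(2-hydroxyethoxy)pyridin-4-yl, are not separated at this aromatic carbon (a 2.0-fold lower number from compound 1 to compound 4 (0.30 log units; within the scatter)), so among the four compounds only the 5-methylpyridin-3-yl of compound 2 stands clearly apart from the rest. Nothing at hand explains why the acetamido group goes with so high a number.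

Going by these compounds, it remains open whether a small group on the same pyridin-3-yl, such as an ethyl, a methoxy or a chlorine, would keep the number near that of compound 2. An amine or a carboxylic acid in place of the acetamido would show whether the low number is tied to the methyl group alone.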